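A few compounds are considered here, and "the series" means these few. Any claim that something is new, unique, unknown or untested is made for them only; others in the source may bear on it.

Working notes on the series. Compound 1 `COc1ccc(C2=C(c3cc(OC)c(OC)c(OC)c3)C(=O)C(OC(C)=O)C2)cc1F` in an ADME assay on HT-29 cells (Homo sapiens) for cytotoxicity, read by MTT assay, with a stated time of 72 h (on this read-out higher numbers stand for weaker inhibition and lower numbers for stronger inhibition), gives < 1 ug/mL, which is a limit of the assay rather than a number (the limit of < 1 ug/mL in this assay, at which 1 of the 2 values shown sits). Compound 2 `COc1ccc(C2=C(c3cc(OC)c(OC)c(OC)c3)C(=O)CC2C)cc1C(=O)O` in this assay gives > 100 ug/mL, likewise a limit (the limit of > 100 ug/mL in this assay, at which 1 of the 2 values shown sits). Within the data shown here, compound 1 therefore stands at the strong end of what has been recorded, with no exact number behind it, and no step between two measured compounds is available to calibrate a change. Compound 3 `COc1ccc(C2=C(c3cc(OC)c(OC)c(OC)c3)C(=O)C(OC(C)=O)C2)cc1O` differs from compound 1 by hydroxy in place of fluoro on an aromatic carbon. For compound 3 the step that the limit leaves unreadable from compound 1 to compound 3 is expected to stay within the usual scatter, with no clear direction. Compound 3 is estimated at 0.5 ug/mL, between 0.1 ug/mL and 3 ug/mL.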

Compound 3, half-maximal inhibitory concentration: < 1 ug/mL
Compound 3 was reported as a limit; the forecaster's own chance of this, stated with the estimate: 40%; the middle value is on the limit's open side.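

No step can be read from compound 1 to compound 3, because both values are limits of the assay and not numbers: the limit of < 1 ug/mL in this assay, at which 2 of the 3 values shown sit. The compounds shown leave open whether hydroxy in place of fluoro on an aromatic carbon changes the inhibition at all.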